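The compounds below may be only part of what the source reports. "The series", "measured", "known", "first", "only" and "open" are said of these compounds alone.

Measured compounds in a functional assay on CCRF-CEM cells (Homo sapiens) for cytotoxicity, read by MTT assay, with a stated time of 72 h; on this read-out higher numbers stand for lower toxicity in this test and lower numbers for higher toxicity in this test:
Compound 1, `COc1ccc(CNc2nc([SeH])nc3ccccc23)cc1`, stands at the limit of the test, > 100000 nM.
Compound 2, `CSc1ccc(CNc2nc([SeH])nc3ccccc23)cc1`, stands at the limit of the test, > 100000 nM.
Compound 3, `[SeH]c1nc(NCc2ccccc2)c2ccccc2n1`, stands at the limit of the test, > 100000 nM.

Compound 2 therefore gives no number in this assay, only a limit, and the same holds for the other two compounds shown, as summed up by the limit of > 100000 nM in this assay, at which 3 of the 3 values shown sit. The steps among them cannot be sized: a step that the two limits leave unreadable from compound 1 to compound 2, a step that the two limits leave unreadable from compound 2 to compound 3 and a step that the two limits leave unreadable from compound 1 to compound 3 are all unreadable between two limits.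

Compound 4, `CSc1ccc(CNc2nc([Se]C)nc3ccccc23)cc1`, differs from compound 2 by methyl in place of hydrogen on a selenium. Going by the values given here, none of the measured steps touches the selenium; all three vary the substituent on the aromatic carbon and leave the selenium with its hydrogen, so no measured step bears directly on this change, and none of them yields a readable size in any case. With every value sitting at the limit, compound 4 is expected to stay near that limit too, a step that the limit leaves unreadable from compound 2 to compound 4 being the estimate. For compound 4 the estimated value is 150000 nM, with a range from 30000 nM to 600000 nM.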

Compound 4, concentration lethal to 50% of the cells: > 100000 nM
Compound 4: no number, only a limit (the forecaster's own chance of this, stated with the estimate: 70%); the middle value lies beyond the limit too.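

In this assay compound 4 gives only a limit, > 100000 nM. Compound 2 gives no number either, so no new step can be read between these two compounds. The compounds shown leave open the actual toxicity of each one, and whether methyl in place of hydrogen on a selenium changes it at all.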